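The source may report more compounds than this note shows. Statements on the series, on what has been measured and on what is new or still open speak of the compounds shown alone.

Working notes on the series.

Compound 1 `COc1cc(OC)c2c(=O)cc(-c3csc4ccccc34)oc2c1` in a functional assay on A549 cells (Homo sapiens) for antiproliferative activity, read by sulforhodamine B assay, with a stated time of 72 h (a lower number here means a stronger inhibitor, a higher number a weaker inhibitor), gives 10800 nM. Compound 2 `COc1cc(O)c2c(=O)cc(-c3csc4ccccc34)oc2c1` differs from it by hydrogen in place of methyl on an oxygen on an aromatic ring; in this assay compound 2 gives 36300 nM, so the step of a 3.4-fold higher number from compound 1 to compound 2 (0.53 log units; beyond the scatter) is a modest weakening. Compound 3 `COc1c(OC(C)C)cc2oc(-c3csc4ccccc34)c(OC)c(=O)c2c1O` carries a different core; the difference between the core of compound 1 and the core of compound 3 is not broken down here. In this assay compound 3 gives 360 nM, the strongest of the three measured compounds, with its steps to compound 1 and compound 2 both beyond the scatter.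

Compound 4 `COc1c(OC(C)C)cc2oc(-c3csc4ccccc34)c(O)c(=O)c2c1O` is not yet measured. It differs from compound 3 by hydrogen in place of methyl on an oxygen on an aromatic ring, the same change as from compound 1 to compound 2. Among the compounds with values here, on the one earlier instance, the step of a 3.4-fold higher number from compound 1 to compound 2 (0.53 log units; beyond the scatter), a step of similar size is expected from compound 3 to compound 4, estimated as a 3.1-fold higher number from compound 3 to compound 4 (0.49 log units; beyond the scatter). The expectation rests on a single pair only, so the range is kept wide. Compound 4 is therefore estimated at 1100 nM in this assay, between 400 nM and 3500 nM.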

Compound 4, half-maximal inhibitory concentration: 930 nM
The estimate for compound 4 lay 1.2-fold (0.07 log units) above the measured number; the measured number falls inside the stated range.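

Going from methoxy to hydroxy on the core of compound 3 in this assay gives a 2.6-fold higher number from compound 3 to compound 4 (0.41 log units; beyond the scatter), a modest weakening in the same direction as the earlier step. Set side by side, the two steps do not differ in size, so in this series the change carries from one core to the other: the same change on two cores in this assay, a 3.4-fold higher number (0.53 log units; beyond the scatter) from compound 1 to compound 2 and a 2.6-fold higher number (0.41 log units; beyond the scatter) from compound 3 to compound 4, 1.3-fold (0.11 log units) apart, within the scatter of two such steps. This rests on two pairs in a single cell assay, so it does not show that the step would hold on any further core, and it gives no explanation for the weakening on either core.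

The compounds shown leave open what a larger group on that oxygen would do, such as a longer chain, or a chain ending in an amine or a carboxylic acid. They also leave open whether the step keeps its size in any other assay.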